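From methoxy to butoxy: compound 3 to compound 4

A few compounds are considered here, and "the series" means these few. Any claim that something is new, unique, unknown or untested is made for them only; others in the source may bear on it.

In an ADME assay on HepG2 cells (Homo sapiens) for cytotoxicity, read by luminescence, with a stated time of 72 h (a lower number here means that less compound is needed, a higher number that more compound is needed for the effect), compound 1 (`CCOC(=O)c1c(-c2cccc(C)c2)[nH]c2cc(OC)ccc2c1=O`) gives > 21500 nM as a limit. Compound 2 (`C=Cc1cccc(-c2[nH]c3cc(OC)ccc3c(=O)c2C(=O)OCC)c1`) gives > 21500 nM as a limit too. Compound 3 (`CCOC(=O)c1c(-c2cccc(OC)c2)[nH]c2cc(OC)ccc2c1=O`) gives > 21500 nM as a limit as well. It therefore has no exact number, and its place is the limit of > 21500 nM in this assay, at which 3 of the 3 values shown sit, in the series. Compound 4 (`CCCCOc1cccc(-c2[nH]c3cc(OC)ccc3c(=O)c2C(=O)OCC)c1`) carries butoxy for methoxy (propyl in place of hydrogen on a saturated chain carbon bound to an oxygen on an aromatic ring). The measured steps that bear on this are a step that the two limits leave unreadable from compound 1 to compound 3 and a step that the two limits leave unreadable from compound 2 to compound 3 and they give no size to carry over. No step beyond the scatter is therefore expected in this assay and no direction can be foreseen. The estimated change is small (a step that the limit leaves unreadable from compound 3 to compound 4). Compound 4 is estimated at 22000 nM (range 10000 nM to 45000 nM).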

Compound 4, half-maximal effective concentration: > 21500 nM
Compound 4: a limit, no number (the forecaster's own chance of this, stated with the estimate: 75%); the middle value is on the limit's open side.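

In this assay, for the compounds shown here, compound 1, compound 2, compound 3 and compound 4 all give only a limit, so no step among them can be read. From the compounds shown here alone, how much of each is needed for the effect, and whether changing the group alters that amount, stays open.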